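The source may hold more compounds than are shown below. What is called first, only, known or untested is meant among the compounds shown, and "the series" means these compounds.

Measured so far in an ADME assay on microsomes from liver (Macaca fascicularis) for metabolic stability, read by LC-MS, with a stated time of 65 min, tested at 1 uM; a lower number here means that less of the compound is left, a higher number that more of the compound is left:
- compound 1 `Cc1ncncc1-c1nc2cc(F)c(F)cc2n1C1CC1` gives 72%
- compound 2 `Fc1cc2nc(-c3cncnc3NCCC(F)(F)F)n(C3CC3)c2cc1F` gives 55%
- compound 3 `Fc1cc2nc(-c3cncnc3C(F)F)n(C3CC3)c2cc1F` gives 106%

Compound 3 stands highest of the three. Compound 4 `Fc1cc2nc(-c3cncnc3C(F)(F)F)n(C3CC3)c2cc1F` differs from it in one place (difluoromethyl to trifluoromethyl): fluoro in place of hydrogen on a saturated chain carbon bound to an aromatic carbon and two fluorine atoms. In words, this is fluoro in place of hydrogen on a saturated chain carbon bound to an aromatic carbon and two fluorine atoms.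

The closest evidence is the large step from methyl to difluoromethyl (a number 34 percentage points higher from compound 1 to compound 3 (beyond the scatter)). The steps involving (3,3,3-trifluoropropyl)amino (a number 17 percentage points lower from compound 1 to compound 2 (beyond the scatter) and a number 51 percentage points higher from compound 2 to compound 3 (beyond the scatter)) concern a different group and bear less. Within the data shown here, no measured step adds a single fluoro to difluoromethyl, and compound 3 (106%) leaves little room upward. In this assay the expected step is a slight fall, within the scatter (a number 8 percentage points lower from compound 3 to compound 4 (within the scatter)). Compound 4 is estimated at 98% (range 80% to 112%).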

Compound 4, percent of the compound remaining: 99%
Compound 4: middle estimate off by 1 percentage points, on the low side; the measured number falls inside the stated range.
By their numbers in this assay, from the lowest: compound 2; then compound 1; then compounds 4 and 3 (each within the scatter of the next).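

Fluoro in place of hydrogen on this saturated chain carbon gives a number 7 percentage points lower from compound 3 to compound 4 (within the scatter) in this assay, so difluoromethyl and trifluoromethyl cannot be told apart in this assay. Trifluoromethyl also gives a number 27 percentage points higher from compound 1 to compound 4 (beyond the scatter) and a number 44 percentage points higher from compound 2 to compound 4 (beyond the scatter), so with difluoromethyl there are now two fluorinated groups on this aromatic carbon that leave more compound than methyl or (3,3,3-trifluoropropyl)amino. No measurement shown here explains these numbers.

Going by these compounds, whether a nitrile, a carboxylic acid or a longer fluorinated chain such as pentafluoroethyl on this aromatic carbon would leave as much compound remains open.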